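Amino for Chloro on a Compound at the Assay Limit

A few compounds are considered here, and "the series" means these few. Any claim that something is new, unique, unknown or untested is made for them only; others in the source may bear on it.

Compound 1, `ClCc1cccc(Cn2cnc3c(Cl)nc(Cl)nc32)c1`, was tested in a functional assay on RPMI-8226 cells (Homo sapiens) for cytotoxicity, read by sulforhodamine B assay, with a stated time of 48 h; on this read-out higher numbers stand for weaker inhibition of growth and lower numbers for stronger inhibition of growth. In this assay compound 1 reached only > 100000 nM, which is a limit of the assay and not a measured number. Among the values shown, compound 1 stands at the limit of > 100000 nM in this assay, at which 1 of the 2 values shown sits. Compound 2, `ClCc1ccccc1Cn1cnc2c(Cl)nc(Cl)nc21`, gives 1540 nM in this assay. Compound 3, `Nc1nc(Cl)c2ncn(Cc3cccc(CCl)c3)c2n1`, is not yet measured; it differs from compound 1 by amino in place of chloro on an aromatic carbon. Among the compounds with values here, no measured step of this kind exists here, so the change is expected to bring little or nothing beyond the scatter, with the step of an at least 1.6-fold lower number from compound 1 to compound 3 (0.22 log units; that floor lies within the scatter). Compound 3 is therefore estimated at 60000 nM, within 8000 nM to 100000 nM.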

Compound 3, concentration for total growth inhibition: 11800 nM
Beside the measured number, compound 3's estimate is 5.1-fold (0.71 log units) above it; the range from low to high includes it.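

In this assay, within the data shown here, amino in place of chloro on this aromatic carbon, between two ring nitrogen atoms, gives an at least 8.4-fold lower number from compound 1 to compound 3 (0.92 log units; beyond the scatter), so this position responds to a change, which the earlier compounds could not show. Compound 1 gives only a limit of the assay, not a number: the limit of > 100000 nM in this assay, at which 1 of the 3 values shown sits. On these data alone, the step is thus a minimum, and its true size stays unknown.

As far as these compounds go, whether amino is special here stays open; a methoxy group or a methylamino group at this place would test that. From the compounds shown here alone, whether the same change would also move compound 2 stays open too.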